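Swapping the aryl group on the thioether of compound 2

The source may hold more compounds than are shown below. What is called first, only, known or untested is meant among the compounds shown, and "the series" means these compounds.

Compound 2, with the structure `Cc1cc(C)cc(SCc2ccc(/C=C/C(=O)Nc3ccccc3N)cc2)c1`, is the weakest of three measured compounds in a functional assay on A-375 cells (Homo sapiens) for inhibition, read by CCK-8 assay, with a stated time of 72 h, tested at 2 uM; a higher number here means more inhibition of growth at the concentration tested, a lower number less inhibition of growth: compound 2 gives 8.78%. Its nearest neighbour in this assay is compound 3, `CCc1ccc(SCc2ccc(C(=O)Nc3ccccc3N)cc2)cc1`, for which compound 3 gives 19.6%, a number beyond the usual scatter above that of compound 2. Furthest away stands compound 1, `Nc1ccccc1NC(=O)c1ccc(CSc2nccc(C(F)(F)F)n2)cc1`, and in this assay compound 1 gives 54.4%. Going by the values given here, compound 3 is the only measured compound that carries a 4-ethylphenyl on the sulfur, though it lacks the vinyl spacer of compound 2.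

The unmeasured compound 4, `CCc1ccc(SCc2ccc(/C=C/C(=O)Nc3ccccc3N)cc2)cc1`, keeps the vinyl-bearing core of compound 2 and differs from it only at one position: 4-ethylphenyl in place of 3,5-dimethylphenyl on a sulfur. Among the compounds with values here, no measured pair shows this change directly. Because compound 3 gives 19.6% with the same 4-ethylphenyl group, the expected step from compound 2 to compound 4 is a small one upward, a number 6.2 percentage points higher from compound 2 to compound 4 (within the scatter), which may well stay within the scatter. Compound 4 is therefore expected to reach about 15%, with a plausible range from 3% to 35%.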

Compound 4, percent growth inhibition at one concentration: 5.27%
Compound 4: the middle estimate sits 9.7 percentage points above what was measured, within the range that was stated.
By their numbers in this assay, from the lowest: compounds 4 and 2 (each within the scatter of the next); then compound 3; then compound 1.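

In this assay, 4-ethylphenyl in place of 3,5-dimethylphenyl on a sulfur, with the vinyl-bearing core held fixed, gives a number 3.5 percentage points lower from compound 2 to compound 4 (within the scatter), so this direct comparison does not separate the two aryl groups. The result also supplies a second pair that differs in one place, since 4-ethylphenyl sits on the sulfur in both members and only the vinyl spacer sets them apart: compound 3 gives 19.6% and compound 4 gives 5.27%, a single pair that sets no general rule for the spacer. No measurement shown here bears on why the aryl change leaves the number within the scatter or why these values stand where they do.

The compounds shown leave open whether the trifluoromethyl-bearing ring on the sulfur of compound 1, which gives 54.4%, would hold its number on the vinyl-bearing core, since compound 1 differs from compound 4 in more than one place. They also leave open how an amine, a carboxylic acid or a chain longer than ethyl on the aryl ring would read at this position, and whether an oxygen could stand in place of the sulfur.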